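The source may report more compounds than this note shows. Statements on the series, on what has been measured and on what is new or still open speak of the compounds shown alone.

Compound 1 `COC(=O)N1CCCc2cc(S(=O)(=O)N3CC(c4ccccc4)NC3=O)ccc21`: in a functional assay on cells (KATO III cell, Homo sapiens) for antiproliferative activity, read by MTT assay (a higher number here means a weaker inhibitor, a lower number a stronger inhibitor), compound 1 gives 16500 nM.
Compound 2 `CCCOC(=O)N1CCCc2cc(S(=O)(=O)N3CC(c4ccccc4)NC3=O)ccc21`: in this assay compound 2 gives 3300 nM.

Compound 2 holds the lower of these two numbers. Among the measured compounds shown here, the only measured step, a 5.0-fold lower number from compound 1 to compound 2 (0.70 log units; beyond the scatter), lengthened the same chain and lowered the number. Compound 3 `CCCCOC(=O)N1CCCc2cc(S(=O)(=O)N3CC(c4ccccc4)NC3=O)ccc21` differs from compound 2 by methyl in place of hydrogen on a saturated chain carbon, three bonds along the chain from an oxygen next to a carbonyl group. Since that earlier lengthening helped, a further, smaller lowering is expected for compound 3, with an estimated step of a 1.7-fold lower number from compound 2 to compound 3 (0.22 log units; within the scatter). For the measured compounds named here, the single measured step gives little to lean on. Compound 3 is therefore estimated at 2000 nM in this assay, within a range of 700 nM to 6000 nM.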

Compound 3, half-maximal inhibitory concentration: 4010 nM
For compound 3 the middle estimate is 2.0-fold (0.30 log units) below the measured one; the range from low to high includes it.
By their numbers in this assay, from the lowest: compounds 2 and 3 (each within the scatter of the next); then compound 1.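

Going one carbon further, from propyl to butyl, gives a 1.2-fold higher number from compound 2 to compound 3 (0.08 log units; within the scatter), so in this assay these two chains cannot be told apart. The lowering seen on moving up from the shortest chain therefore does not continue past propyl, though butyl keeps most of it, with a 4.1-fold lower number from compound 1 to compound 3 (0.61 log units; beyond the scatter). No measurement here explains this dependence on chain length.

From the compounds shown here alone, whether a longer chain such as hexyl would hold the number or lose ground remains open. So does the effect of a branched chain such as isopropyl, or of an amine at the chain's end.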